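Arylidene aryl swap: dimethylamino to dimethoxy

The source may hold more compounds than are shown below. What is called first, only, known or untested is meant among the compounds shown, and "the series" means these compounds.

Measured so far in a functional assay on ECa-109 cells (Homo sapiens) for cytotoxicity, read by MTT assay, with a stated time of 72 h; on this read-out higher numbers stand for weaker inhibition and lower numbers for stronger inhibition:
Compound 1 `O=C1C(=Cc2ccc(O)cc2)C(=O)N(c2ccc(Cl)cc2)N1c1ccc(Cl)cc1`: 34200 nM
Compound 2 `CN(C)c1ccc(C=C2C(=O)N(c3ccc(Cl)cc3)N(c3ccc(Cl)cc3)C2=O)cc1`: > 128000 nM, a limit of the assay
Compound 3 `O=C1C(=Cc2ccc(Cl)cc2)C(=O)N(c2ccc(Cl)cc2)N1c1ccc(Cl)cc1`: 17300 nM

Compound 2 stands at the weak end of the three: its result is a limit of the assay, not a number, so only a lower bound for its step to the others is known. Among the compounds with values here, two steps touch it directly: an at least 3.7-fold higher number from compound 1 to compound 2 (0.57 log units; beyond the scatter) and an at least 7.3-fold lower number from compound 2 to compound 3 (0.86 log units; beyond the scatter). Both lie beyond the scatter, and both point the same way, with the limit of > 128000 nM in this assay, at which 1 of the 3 values shown sits, fixing how far they can be read. Between compound 1 and compound 3 the change is a 2.0-fold lower number from compound 1 to compound 3 (0.30 log units; within the scatter), so the hydroxy and chloro compounds sit together below compound 2.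

Compound 4 `COc1ccc(C=C2C(=O)N(c3ccc(Cl)cc3)N(c3ccc(Cl)cc3)C2=O)cc1OC` differs from compound 2 by 3,4-dimethoxyphenyl in place of 4-(dimethylamino)phenyl on a double-bonded chain carbon bound to a double-bonded ring carbon. Within the data shown here, compound 2 is the only measured example of a dimethylamino group at this place, and every replacement so far has brought the number down, so a lowering step is expected, roughly an at least 2.8-fold lower number from compound 2 to compound 4 (0.45 log units; beyond the scatter). For compound 4 the estimate in this assay is 45000 nM, within 15000 nM to 128000 nM.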

Compound 4, half-maximal inhibitory concentration: > 128000 nM
Compound 4 was reported as a limit; the forecaster's own chance of this, stated with the estimate: 25%; middle value at least 2.8-fold (0.45 log units) from the limit.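

In this assay compound 4 gives > 128000 nM, which is a limit of the assay and not a number. At this place on a double-bonded chain carbon, 3,4-dimethoxyphenyl therefore falls on the weak side along with 4-(dimethylamino)phenyl, so a replacement of the dimethylamino group no longer always brings the number down, with an at least 7.3-fold higher number from compound 3 to compound 4 (0.86 log units; beyond the scatter) and an at least 3.7-fold higher number from compound 1 to compound 4 (0.57 log units; beyond the scatter). The step between compound 2 and compound 4 cannot be read, since both results rest on the same limit: the limit of > 128000 nM in this assay, at which 2 of the 4 values shown sit.

Going by these compounds, how far compound 2 and compound 4 lie past that limit remains open, so no order between them can be given. Also open, on these data alone, is whether 4-methoxyphenyl or 4-nitrophenyl at this place would stay with compound 1 and compound 3 or join the two limit compounds.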